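The source may report more compounds than this note shows. Statements on the series, on what has been measured and on what is new or still open speak of the compounds shown alone.

Measured in an assay on isolated protein for inhibition of NUAK family SNF1-like kinase 1 (Homo sapiens), read by ADP-Glo, with a stated time of 60 min, tested at 10 uM, in the presence of a further agent that is not named here; on this read-out lower numbers stand for less inhibition and higher numbers for more inhibition at the one concentration tested (going by the name of the read-out):
compound 1 `CCCN(CCC)c1ccc(Nc2ncc(Cl)c(Oc3cccc(NC(=O)CC)c3)n2)cc1` gives 9.3%
compound 2 `CCC(=O)Nc1cccc(Oc2nc(Nc3ccc(N4CCN(C)CC4)cc3)ncc2Cl)c1` gives 92.9%
compound 3 `CCC(=O)Nc1cccc(Oc2nc(Nc3ccc(N4CCN(C)CC4)cc3Cl)ncc2Cl)c1` gives 71.5%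

Compound 2 stands highest of the three numbers, with compound 3 nearest and compound 1 furthest. The two steps are a number 83.6 percentage points higher from compound 1 to compound 2 (beyond the scatter) and a number 21.4 percentage points lower from compound 2 to compound 3 (beyond the scatter); both are beyond the scatter.

Compound 4 `CCC(=O)Nc1cccc(Oc2nc(Nc3ccc(N(C)C)cc3)ncc2Cl)c1` is not yet measured. It differs from compound 2 in one place: dimethylamino in place of 4-methylpiperazin-1-yl on an aromatic carbon

Among the measured compounds shown here, the step that bears on this change is a number 83.6 percentage points higher from compound 1 to compound 2 (beyond the scatter), the only one that exchanges the amine at this aromatic carbon; the step of a number 21.4 percentage points lower from compound 2 to compound 3 (beyond the scatter) concerns another position and says little here. Only two amines are known at this site, one giving a low reading and one a high one, so where dimethylamino falls between them is open. A downward step from compound 2 is expected, of uncertain size, since dimethylamino is, like dipropylamino, an acyclic amine. For compound 4 the expected step is a number 47.9 percentage points lower from compound 2 to compound 4 (beyond the scatter). Compound 4 is estimated at 45%, in the range 12% to 80%.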

Compound 4, a percentage reported as inhibition, at one concentration (the size of the read-out at that concentration, not a potency): 72.6%
Compound 4: the middle estimate sits 27.6 percentage points below what was measured; low and high end bracket the measured number.
By their numbers in this assay, from the lowest: compound 1; then compounds 3 and 4 (each within the scatter of the next); then compound 2.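

In this assay, a high reading at this aromatic carbon does not depend on the 4-methylpiperazin-1-yl ring: the step to dimethylamino, which has no ring, is only a number 20.3 percentage points lower from compound 2 to compound 4 (beyond the scatter), much smaller than the gap left by dipropylamino in compound 1. Having no ring does not by itself give the low reading, as the exchange among the two acyclic amines alone gives a number 63.3 percentage points higher from compound 1 to compound 4 (beyond the scatter). No measurement offered here accounts for these differences.

Diethylamino at this carbon would show where the reading falls along the acyclic amines between dimethylamino and dipropylamino. Morpholin-4-yl or piperidin-1-yl would test whether the second ring nitrogen of the piperazine matters, and all readings here come from one concentration, so potency remains open.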